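Amino in place of chloro: from compound 1 to compound 4

A few compounds are considered here, and "the series" means these few. Any claim that something is new, unique, unknown or untested is made for them only; others in the source may bear on it.

compound 1 `ClCc1ccccc1Cn1cnc2c(Cl)nc(Cl)nc21`: > 100000 nM
compound 2 `Nc1nc(Cl)c2ncn(Cc3ccc(CCl)cc3)c2n1`: 63100 nM
compound 3 `ClCc1cccc(Cn2cnc3c(Cl)ncnc32)c1`: > 100000 nM

In a functional assay on NCI-H460 cells (Homo sapiens) for cytotoxicity, read by sulforhodamine B assay, with a stated time of 48 h (a lower number here means that less compound is tolerated, a higher number that more compound is tolerated), compound 1 stands at a limit: its reading of > 100000 nM is a limit of the assay and not a number. Compound 3 likewise returns only a limit, > 100000 nM. Compound 2 gives a numerical reading of 63100 nM in this assay. Going by the values given here, two of the three readings therefore sit at the assay's limit (the limit of > 100000 nM in this assay, at which 2 of the 3 values shown sit), and compound 2 is the only measured compound with a number.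

Compound 4 `Nc1nc(Cl)c2ncn(Cc3ccccc3CCl)c2n1` is not yet measured. It differs from compound 1 in one place: amino in place of chloro on an aromatic carbon. Among the compounds with values here, no measured pair shows this change alone, so its size is not known from the data. Compound 2 carries the same amino group on the shared core and gives 63100 nM, but compound 2 and compound 4 also differ elsewhere, so this is not a one-place step.

Compound 4 is expected to land near 70000 nM, with a range of 30000 nM to 200000 nM, and a fair chance that only a limit is reported. The expected step from compound 1 to compound 4 is estimated at an at least 1.4-fold lower number from compound 1 to compound 4 (0.15 log units; that floor lies within the scatter), a move toward a numerical reading rather than a limit, but not one that can be called beyond the scatter with confidence.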

Compound 4, concentration lethal to 50% of the cells: > 100000 nM
Compound 4: no number, only a limit (the forecaster's own chance of this, stated with the estimate: 40%); middle value at least 1.4-fold (0.15 log units) from the limit.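

Compound 4 returns only a limit in this assay, as compound 1 does, so no step can be read for amino in place of chloro: the limit of > 100000 nM in this assay, at which 3 of the 4 values shown sit.

The compounds shown leave open whether this change alters the reading at all, and by how much.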